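A few compounds are considered here, and "the series" means these few. Any claim that something is new, unique, unknown or untested is made for them only; others in the source may bear on it.

Measured so far in an assay for inhibition of Tryptophan 2,3-dioxygenase (Homo sapiens), with stated times of 10 min and 60 min; on this read-out higher numbers stand for weaker inhibition and lower numbers for stronger inhibition:
compound 1 `FC(F)(F)c1cc(NC[C@H]2CCCN2)c2cn[nH]c2c1` gives 6090 nM
compound 2 `Oc1ccc(CNc2cc(C(F)(F)F)cc3[nH]ncc23)c(Cl)c1` gives 2680 nM
compound 3 `O=C1NCc2c(NCc3ccccc3[N+](=O)[O-])cccc21` gives only > 100000 nM, a limit of the assay and not a number

Of the two numbers in this assay, compound 1 stands at the higher one; compound 2 sits lower by a gap beyond the usual scatter. Compound 3 contributes only (the limit of > 100000 nM in this assay, at which 1 of the 3 values shown sits).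

Not yet measured is compound 4 `FC(F)(F)c1cc(NC[C@@H]2CCCCN2)c2cn[nH]c2c1`. It differs from compound 1 by piperidin-2-yl in place of pyrrolidin-2-yl on a saturated chain carbon bound to a nitrogen on an aromatic ring. Among the measured compounds shown here, no measured pair shows this change, so its size cannot be read from the numbers in hand; the expectation is a step within the scatter, with no clear direction. Compound 4 is therefore estimated at 5500 nM in this assay, within a range of 1500 nM to 20000 nM, an expected step of a 1.1-fold lower number from compound 1 to compound 4 (0.04 log units; within the scatter).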

Compound 4, half-maximal inhibitory concentration: 8050 nM
Beside the measured number, compound 4's estimate is 1.5-fold (0.17 log units) below it; low and high end bracket the measured number.
By their numbers in this assay, from the lowest: compound 2; then compounds 1 and 4 (each within the scatter of the next). At a limit, above all of these: compound 3.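

In this assay, among the compounds shown here, piperidin-2-yl in place of pyrrolidin-2-yl on the saturated chain carbon gives a 1.3-fold higher number from compound 1 to compound 4 (0.12 log units; within the scatter), the first reading of a single change at this position. The ring on this carbon can therefore take this change without a step beyond the scatter, though inhibition stays in the same range. No measured property in hand bears on this result.

Open, from the compounds shown here alone, is how a smaller ring such as azetidin-2-yl, an open-chain amine or a carboxylic acid would read at this position. Also open, going by these compounds, is how the opposite configuration at the stereocentre of either ring would read.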